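Swapping an Ester for an Amide on Compound 2

The compounds below may be only part of what the source reports. "The series", "measured", "known", "first", "only" and "open" are said of these compounds alone.

Compound 1 `COC(=O)c1cnc(C(O)CCCCCCc2ccccc2)o1` carries a methyl ester directly on the shared core, next to the long alcohol-bearing chain. In an assay (Rattus norvegicus) for inhibition of Fatty-acid amide hydrolase 1 (Homo sapiens) (a lower number here means a stronger inhibitor, a higher number a weaker inhibitor), compound 1 gives 2000 nM. Compound 2 `COC(=O)c1ccc(-c2cnc(C(O)CCCCCCc3ccccc3)o2)nc1` keeps the same chain but lengthens the link between the core and the ester. In this assay compound 2 reaches only > 10000 nM, which is a limit of the measurement and not a true number. Of the two measured compounds, one therefore sits at that edge: the limit of > 10000 nM in this assay, at which 1 of the 2 values shown sits.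

Compound 3 `NC(=O)c1ccc(-c2cnc(C(O)CCCCCCc3ccccc3)o2)nc1` is the still unmeasured partner of compound 2. The change is amino in place of methoxy on a carbonyl carbon, in words, amino in place of methoxy on a carbonyl carbon; cut one bond further out, it reads methoxycarbonyl to carbamoyl. Among the compounds with values here, no measured pair shows this change, so its size rests on judgement alone. The step of a number no higher from compound 2 to compound 3 (the limit leaves the size open) is expected to be small, with no clear direction beyond the usual scatter. Compound 3 is accordingly estimated at 10000 nM, within a range from 3000 nM to 30000 nM, and a limit rather than a number remains the likeliest outcome.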

Compound 3, inhibition constant: 3000 nM
Compound 3: the middle estimate sits 3.3-fold (0.52 log units) above what was measured, and the stated range covers the measured number.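

In this assay, what sits on this carbonyl carbon clearly matters, as amino in place of methoxy gives an at least 3.3-fold lower number from compound 2 to compound 3 (0.52 log units; beyond the scatter), a step beyond the scatter. Within the data shown here, this is the first sign that a compound with the longer link to the carbonyl can give a real number in this assay, although the full size of the step cannot be read, since its starting point is a limit of the assay and not a number: the limit of > 10000 nM in this assay, at which 1 of the 3 values shown sits. The comparison with the first compound adds a second point, a 1.5-fold higher number from compound 1 to compound 3 (0.18 log units; within the scatter), which lies within the scatter, so 5-carbamoylpyridin-2-yl and methoxycarbonyl on an aromatic carbon cannot be told apart here.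

The compounds shown leave open whether other groups on this carbonyl carbon, such as hydroxy or methylamino, would match amino, and whether a nitrile could take the place of the whole carbamoyl group. As far as these compounds go, they also leave open what amino in place of methoxy would do on compound 1, where the carbonyl sits directly on the shared core, so it is unknown whether this step holds beyond the longer link.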